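Shifting the aryl substituent on the pyrrolidine amide

The source may report more compounds than this note shows. Statements on the series, on what has been measured and on what is new or still open speak of the compounds shown alone.

Measured so far, in an assay on isolated protein for inhibition of Rho-associated protein kinase 2 (Homo sapiens), read by a luciferase reporter; on this read-out higher numbers stand for weaker inhibition and lower numbers for stronger inhibition:
Compound 1 `O=C(Nc1cc2cc[nH]c(=O)c2cc1Cl)C1CNCC1c1ccc(F)cc1` gives 9 nM.
Compound 2 `O=C(Nc1cc2cc[nH]c(=O)c2cc1Cl)C1CNCCC1c1ccccc1` gives 6 nM.
Compound 3 `O=C(Nc1cc2cc[nH]c(=O)c2cc1Cl)[C@@H]1CCCNC1` gives 47 nM.

All three share the same core, an amide carrying a chlorinated bicyclic lactam, and differ in the saturated ring attached to the amide carbonyl. Compound 1 stands second highest of the three numbers. Its nearest neighbour is compound 2, whose number lies within the usual scatter of compound 1, so the two cannot be told apart. Compound 3, which carries no aryl group on its saturated ring, gives a number well beyond the scatter above compound 1.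

Compound 4 `O=C(Nc1cc2cc[nH]c(=O)c2cc1Cl)C1CNCC1c1cccc(C(F)(F)F)c1` has not yet been measured. It differs from compound 1 in one place: 3-(trifluoromethyl)phenyl in place of 4-fluorophenyl on a saturated ring carbon. Going by the values given here, no measured pair shows what exchanging one aryl substituent for another does here, so the step from compound 1 to compound 4 is uncertain. A small change in this assay is expected, not clearly beyond the scatter in either direction, with a slight lean toward a higher number. Compound 4 is estimated at 13 nM, within a range of 4 nM to 45 nM, which amounts to an expected step of a 1.4-fold higher number from compound 1 to compound 4 (0.16 log units; within the scatter).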

Compound 4, half-maximal inhibitory concentration: 4 nM
For compound 4 the middle estimate is 3.3-fold (0.51 log units) above the measured one; the range from low to high includes it.
By their numbers in this assay, from the lowest: compounds 4, 2 and 1 (each within the scatter of the next, the first and the last beyond it); then compound 3.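

In this assay, the first pair differing in one place shows that the aryl group on this saturated ring carbon can be exchanged with no loss of inhibition: 3-(trifluoromethyl)phenyl in place of 4-fluorophenyl gives a 2.3-fold lower number from compound 1 to compound 4 (0.35 log units; beyond the scatter), a modest step but one beyond the usual scatter. The entering group has more heavy atoms than the one it replaces, so this position accepts the bigger of these two aryl groups. No measurement shown here speaks to why the number falls.

This single step changes both the substituent and its place on the phenyl ring, so the compounds shown cannot separate the two. Also open, as far as these compounds go, is how a nitrile, a methoxy group or an amine on that phenyl ring would fare.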